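Swapping the quinoline for a thiophene at the ether

This account rests on a few compounds, and the source may have more. Where it says the series, first, only, none or still open, it means among the compounds named here.

Measured compounds:
compound 1 `CC(C)(C)Sc1c(CC(C)(C)C(=O)O)n(Cc2ccc(Cl)cc2)c2ccc(OCc3ccc4cc(F)ccc4n3)cc12` with 880 nM
compound 2 `CC(COc1ccc2c(c1)c(SC(C)(C)C)c(CC(C)(C)C(=O)O)n2Cc1ccc(Cl)cc1)c1ccccn1` with 270 nM

In a functional assay (blood) for inhibition, with Homo sapiens as the target (on this read-out lower numbers stand for stronger inhibition and higher numbers for weaker inhibition), compound 1 stands highest of the two numbers; compound 2 sits nearest, a 3.3-fold lower number from compound 1 to compound 2 (0.51 log units; beyond the scatter). Compound 3 `CC(C)(C)Sc1c(CC(C)(C)C(=O)O)n(Cc2ccc(Cl)cc2)c2ccc(OCc3cccs3)cc12` differs from compound 1 in one place: thiophen-2-yl in place of 6-fluoroquinolin-2-yl on a saturated chain carbon bound to an oxygen on an aromatic ring. For the measured compounds named here, the only measured step bearing on this change is a 3.3-fold lower number from compound 1 to compound 2 (0.51 log units; beyond the scatter), where the same quinoline left and a smaller group entered at the same position. That step was modest. A comparable, modest lowering is therefore expected here, a 2.0-fold lower number from compound 1 to compound 3 (0.29 log units; within the scatter), though the thiophene is not the group tested before. For compound 3 the estimate is 450 nM, within 150 nM to 1400 nM.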

Compound 3, half-maximal inhibitory concentration: > 3000 nM
Compound 3: a limit, no number (the forecaster's own chance of this, stated with the estimate: 3%); at least 6.6-fold (0.82 log units) between middle value and limit.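

In this assay compound 3 gives no number, only a limit: the limit of > 3000 nM in this assay, at which 1 of the 3 values shown sits. Leaving the 6-fluoroquinolin-2-yl therefore does not by itself lower the number at this position, since thiophen-2-yl in its place gives an at least 3.4-fold higher number from compound 1 to compound 3 (0.53 log units; beyond the scatter). What enters matters here, as thiophen-2-yl in place of 1-(pyridin-2-yl)ethyl gives an at least 11-fold higher number from compound 2 to compound 3 (1.04 log units; beyond the scatter). The compounds shown leave open whether a phenyl or a plain pyridin-2-yl on the same saturated chain carbon would behave like the 1-(pyridin-2-yl)ethyl or like the thiophen-2-yl. They also leave open how far the true value of compound 3 lies past its limit.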